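This account rests on a few compounds, and the source may have more. Where it says the series, first, only, none or still open, it means among the compounds named here.

In an ADME assay on HEK293 cells (Homo sapiens) for cytotoxicity, with a stated time of 72 h (a lower number here means that less compound is needed, a higher number that more compound is needed for the effect), compound 1 `C=C[C@@](C)(/C=C/c1ccc(OCc2ccccc2)cc1)CCC=C(C)C` gives > 36600 nM as a limit and not a number. Compound 2 `C=C[C@@](C)(/C=C/c1ccc(O)cc1)CCC(O)C(C)(C)O` gives > 36600 nM as a limit as well. Compound 3 `C=C[C@@](C)(/C=C/c1ccc(O)c(/C=C/c2ccc(F)cc2)c1)CCC=C(C)C` gives > 36600 nM as a limit too. Within the data shown here, compound 1 therefore stands with the whole set (the limit of > 36600 nM in this assay, at which 3 of the 3 values shown sit), and no measured step gives a size for any change. Compound 4 `C=C[C@@](C)(/C=C/c1ccc(Nc2cc(F)cc(F)c2)cc1)CCC=C(C)C` carries (3,5-difluorophenyl)amino in place of benzyloxy on an aromatic carbon, para to a large group ((3,5-difluorophenyl)amino in place of benzyloxy on an aromatic carbon). In this assay the step expected an at least 1.2-fold lower number from compound 1 to compound 4 (0.08 log units; that floor lies within the scatter) is none beyond the scatter, with no direction favoured. For compound 4 the estimate is 30000 nM with a range of 12000 nM to 60000 nM and a reading as a limit is likely.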

Compound 4, half-maximal effective concentration: > 36600 nM
Compound 4: no number, only a limit (the forecaster's own chance of this, stated with the estimate: 65%); at least 1.2-fold (0.08 log units) between middle value and limit.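

In this assay, among these compounds, compound 1 and compound 4 both give only a limit, so no step between them can be read. The compounds shown leave open whether any structural change moves this read-out: the limit of > 36600 nM in this assay, at which 4 of the 4 values shown sit.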